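The source may hold more compounds than are shown below. What is called first, only, known or untested is meant among the compounds shown, and "the series" means these compounds.

In a functional assay on BXPC-3 cells (Homo sapiens) for antiproliferative activity, read by MTT assay, with a stated time of 24 h (a lower number here means a stronger inhibitor, a higher number a weaker inhibitor), compound 1 `CCn1c(C(=O)N[C@@H](CC(=O)OC)C(=O)OC)ccc1C(CC)(CC)c1ccc(OCS(=O)(=O)c2ccccc2)c(C)c1` reaches only a limit of the assay, > 50000 nM. For the measured compounds named here, compound 2 `CCn1c(C(=O)N[C@H](CO)CCO)ccc1C(CC)(CC)c1ccc(OCS(=O)(=O)c2ccccc2)c(C)c1` gives 15900 nM, the only true number so far. Compound 3 `CCn1c(C(=O)N[C@@H](C)C(=O)O)ccc1C(CC)(CC)c1ccc(OCS(=O)(=O)c2ccccc2)c(C)c1` differs from compound 2 as follows: 1-carboxyethyl in place of 3-hydroxy-1-(hydroxymethyl)propyl on an amide-type nitrogen. Going by the values given here, the one measured step bearing on this, an at least 3.1-fold lower number from compound 1 to compound 2 (0.49 log units; beyond the scatter), also changes the group on the amide-type nitrogen, but its size is known only as a bound. A modest step towards a higher number is therefore expected in this assay. Compound 3 is estimated at 28000 nM, within 10000 nM to 70000 nM. The expected step is a 1.8-fold higher number from compound 2 to compound 3 (0.25 log units; within the scatter).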

Compound 3, half-maximal inhibitory concentration: 20800 nM
Estimate against measurement, compound 3: 1.3-fold (0.13 log units) above; low and high end bracket the measured number.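

In this assay, 1-carboxyethyl and 3-hydroxy-1-(hydroxymethyl)propyl on the amide-type nitrogen are not told apart (a 1.3-fold higher number from compound 2 to compound 3 (0.12 log units; within the scatter)). Replacing 1,2-bis(methoxycarbonyl)ethyl with 1-carboxyethyl also gives a change beyond the scatter (an at least 2.4-fold lower number from compound 1 to compound 3 (0.38 log units; beyond the scatter)), as the hydroxylated group did in compound 2. The size of that step remains a bound because compound 1 stands at a limit of the assay: the limit of > 50000 nM in this assay, at which 1 of the 3 values shown sits.

As far as these compounds go, what an amine or a plain alkyl chain on this nitrogen would give remains open, as does the effect of a single methyl ester in place of the carboxylic acid of compound 3.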